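A few compounds are considered here, and "the series" means these few. Any claim that something is new, unique, unknown or untested is made for them only; others in the source may bear on it.

Working notes on the series. In a physicochemical assay for acid dissociation, compound 1 `Fc1ccc(-c2ccc3c(NCCCNCc4ccco4)ccnc3c2)cc1` gives 9.47. Compound 2 `CC(C)Cc1ccc2c(NCCCNCc3ccco3)ccnc2c1` gives 9.47 in this assay, so compound 2 stands level with compound 1 at the digits shown: no change at the digits printed from compound 1 to compound 2 (within the scatter). Compound 3 `FC(F)(F)c1cccc(Cc2ccc3c(NCCCNCc4ccco4)ccnc3c2)c1` is not yet measured. It differs from compound 2 in one place: 3-(trifluoromethyl)phenyl in place of isopropyl on a saturated chain carbon bound to an aromatic carbon. For the measured compounds named here, only the step from compound 1 to compound 2 bears on this, and it exchanged one substituent on an aromatic carbon for another of different size without moving the read-out beyond the scatter. Compound 3 is therefore expected to show no step beyond the scatter either, a number 0.02 log units lower from compound 2 to compound 3 (within the scatter), because the comparable exchange no change at the digits printed from compound 1 to compound 2 (within the scatter) left the read-out unchanged. The estimate for compound 3 in this assay is 9.45, with a range from 9.1 to 9.8.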

Compound 3, acid dissociation constant: 9.47
The estimate for compound 3 lay 0.02 log units below the measured number; the measured number falls inside the stated range.
By their numbers in this assay, from the lowest: compounds 1, 2 and 3 (each within the scatter of the next).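

In this assay, the exchange on a saturated chain carbon bound to an aromatic carbon gives no change at the digits printed from compound 2 to compound 3 (within the scatter). The earlier step covered only an exchange on an aromatic carbon, whereas this one shows that the read-out also holds at this chain carbon when 3-(trifluoromethyl)phenyl, with 10 heavy atoms, a six-membered aromatic ring and fluorine, replaces isopropyl, with 3 heavy atoms and no ring. Nothing at hand explains why the read-out holds through this exchange.

As far as these compounds go, whether an amine or a carboxylic acid at the same chain carbon would also leave the read-out in place remains open. The compounds also leave open which proton the read-out reports and whether any change within the shared core would move it.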